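The compounds below may be only part of what the source reports. "The series", "measured", "known", "first", "only" and "open" are said of these compounds alone.

Compound 1: `CCNCc1cc(C)cc(Nc2nc3ccccc3n2Cc2ccc(C(F)(F)F)cc2)c1O` — 51%
Compound 2: `CCNCc1cc(Cl)cc(Nc2nc3ccccc3n2Cc2ccc(C(F)(F)F)cc2)c1O` — 66%

Of the compounds shown here, two have been measured in an ADME assay on microsomes from liver (Rattus norvegicus) for metabolic stability, read by LC-MS, with a stated time of 30 min, tested at 1 uM; a lower number here means that less of the compound is left, a higher number that more of the compound is left. Compound 1 `CCNCc1cc(C)cc(Nc2nc3ccccc3n2Cc2ccc(C(F)(F)F)cc2)c1O` gives 51% in this assay, and compound 2 `CCNCc1cc(Cl)cc(Nc2nc3ccccc3n2Cc2ccc(C(F)(F)F)cc2)c1O` gives 66%. Among the compounds with values here, of these two numbers, compound 1 stands lowest; the single measured step, a number 15 percentage points higher from compound 1 to compound 2 (beyond the scatter), is modest but beyond the scatter, and it concerns chloro in place of methyl on an aromatic carbon.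

Compound 3 `Cc1cc(CNC(C)(C)C)c(O)c(Nc2nc3ccccc3n2Cc2ccc(C(F)(F)F)cc2)c1` differs from compound 1 at another spot: tert-butyl in place of ethyl on an amine nitrogen. Within the data shown here, no measured step touches this amine nitrogen; the one known step alters a group on an aromatic carbon, so it says nothing about tert-butyl in place of ethyl. With nothing to lean on, no change beyond the scatter is expected from this replacement, and the number for compound 3 is taken to sit near that of compound 1, with a wide range to reflect the lack of evidence. Compound 3 is therefore estimated at 55%, between 35% and 75%. The expected step is a number 4 percentage points higher from compound 1 to compound 3 (within the scatter), within the scatter.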

Compound 3, percent of the compound remaining: 41%
Estimate against measurement, compound 3: 14 percentage points above; measured number inside the range.
By their numbers in this assay, from the lowest: compounds 3 and 1 (each within the scatter of the next); then compound 2.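

Within the data shown here, this result gives the first measured look at the amine nitrogen; the only step known before it concerned a group on an aromatic carbon. In this assay, tert-butyl in place of ethyl on this amine nitrogen gives a number 10 percentage points lower from compound 1 to compound 3 (within the scatter) and so does not set the two compounds apart, even though the entering group has 4 heavy atoms and the leaving group has 2. Nothing at hand explains what happens at this position, and a single pair cannot show how other groups on this nitrogen would behave.

Still open, as far as these compounds go, is whether a longer chain such as n-butyl, a ring such as cyclohexyl, or a chain carrying a hydroxyl group on this amine nitrogen would give a number beyond the scatter from that of compound 1, or whether a free primary amine would do so. Also open is whether tert-butyl on this nitrogen would give the same kind of result in a compound with chloro in place of methyl on the aromatic carbon, as the pair shown here both carry methyl.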